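Methyl on the chain: what compound 3 may show

The source may report more compounds than this note shows. Statements on the series, on what has been measured and on what is new or still open speak of the compounds shown alone.

Compound 1 `COc1cc(NC(C)CCCNc2c(NCCCC(C)Nc3cc(OC)cc4cccnc34)c(=O)c2=O)c2ncccc2c1` — "not determined" (no result reported)
Compound 2 `CCCCOc1c(NCCCNc2cc(OC)cc3cccnc23)c(=O)c1=O` — > 100000 nM (a limit of the assay)

In an ADME assay on HEK-293T cells (Homo sapiens) for cytotoxicity, read by MTT assay, with a stated time of 48 h (a higher number here means a weaker inhibitor, a lower number a stronger inhibitor), compound 2 gave no number, only the assay limit of > 100000 nM. Compound 1 stands in this assay as "not determined" (no result reported). Compound 2 thus rests at the limit (the limit of > 100000 nM in this assay, at which 1 of the 2 values shown sits), with nothing measured to compare against.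

Compound 3 `CCCCOc1c(NCCC(C)Nc2cc(OC)cc3cccnc23)c(=O)c1=O` differs from compound 2 by methyl in place of hydrogen on a saturated chain carbon bound to a nitrogen on an aromatic ring and a saturated chain carbon. Among the measured compounds shown here, no measured step between compounds differing in one place exists here, so no change beyond the usual scatter is expected in either direction. Compound 3 is expected at 150000 nM, ranging from 50000 nM to 500000 nM. The expected step that the limit leaves unreadable from compound 2 to compound 3 is essentially none, most likely again only a limit.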

Compound 3, half-maximal inhibitory concentration: > 100000 nM
Compound 3 gave a limit, no number (the forecaster's own chance of this, stated with the estimate: 85%); the middle value lies beyond the limit too.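

No step can be read between compound 2 and compound 3, because each gives only a limit and no number: the limit of > 100000 nM in this assay, at which 2 of the 3 values shown sit.

The compounds shown leave open whether methyl in place of hydrogen on this chain carbon alters the result in this assay at all.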